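The source may hold more compounds than are shown below. What is called first, only, known or untested is meant among the compounds shown, and "the series" means these compounds.

Compound 1, with the structure `CCCCCCCCCCCCCSC[C@H](NC(C)=O)C(=O)CCl`, is one of the two compounds already measured. In a functional assay on MOLT-3 cells (Homo sapiens) (on this read-out higher numbers stand for weaker inhibition and lower numbers for stronger inhibition), compound 1 gives > 100000 nM, which is a limit of the assay and not a number (the limit of > 100000 nM in this assay, at which 1 of the 2 values shown sits). Compound 2, with the structure `CCCCCCCCCCCCCCSC[C@H](NC(C)=O)C(=O)CCl`, is the other measured compound; in this assay compound 2 gives 8800 nM. The step between them is an at least 11-fold lower number from compound 1 to compound 2 (1.05 log units; beyond the scatter). Compound 2 therefore holds the only real number shown in this assay, the remaining value being a limit.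

Compound 3, with the structure `CCCCCCCCCCCCCCCSC[C@H](NC(C)=O)C(=O)CCl`, differs from compound 2 by methyl in place of hydrogen on a saturated chain carbon, ten or more bonds along the chain from a sulfur. Among the measured compounds shown here, the single measured step that bears on this change is the one from the limit of compound 1 to the number of compound 2, which was of the same kind and large. On that basis a further lowering in this assay is expected for compound 3, although two points cannot tell whether the second such change lowers the number as much as the first did, so the expected step is a 2.9-fold lower number from compound 2 to compound 3 (0.47 log units; beyond the scatter). Compound 3 is accordingly estimated at 3000 nM, within a range from 700 nM to 15000 nM.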

Compound 3, half-maximal inhibitory concentration: 8600 nM
Beside the measured number, compound 3's estimate is 2.9-fold (0.46 log units) below it, and the stated range covers the measured number.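

The same change, methyl in place of hydrogen on a saturated chain carbon, ten or more bonds along the chain from a sulfur, does not repeat its earlier effect in this assay: the first instance gave an at least 11-fold lower number from compound 1 to compound 2 (1.05 log units; beyond the scatter) and the second gives a 1.0-fold lower number from compound 2 to compound 3 (0.01 log units; within the scatter). The ethyl in place of hydrogen that spans the whole series amounts to an at least 11-fold lower number from compound 1 to compound 3 (1.06 log units; beyond the scatter) and, among these three compounds, that span rests on the first instance of the change alone, so compound 2 and compound 3 read as the same within the scatter. The reading at the shortest chain remains a limit and not a number, and it is compound 1 that holds it: the limit of > 100000 nM in this assay, at which 1 of the 3 values shown sits.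

The compounds shown leave open how large the first step really is, and whether a longer chain than that of compound 3 would stay level with it in this assay or move away from it. They also leave open what a hydroxyl group or a carboxylic acid at the far end of the chain would do to the number.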